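Lengthening the amide chain on a shared naphthoquinone-like core

The compounds below may be only part of what the source reports. "The series", "measured", "known", "first", "only" and "open" are said of these compounds alone.

Measured so far, in a functional assay on KB cells (Homo sapiens) for cytotoxicity, read by resazurin assay, with a stated time of 3 days; a lower number here means a stronger inhibitor, a higher number a weaker inhibitor:
compound 1, `CCCCCCCCC(=O)NCC(C)(C)CC1=C(O)C(=O)c2ccccc2C1=O`: 19700 nM
compound 2, `CCCCCCCCCCC(=O)NCC(C)(C)CC1=C(O)C(=O)c2ccccc2C1=O`: 17600 nM
compound 3, `CCCCCCCCCCCC(=O)NCC(C)(C)CC1=C(O)C(=O)c2ccccc2C1=O`: 12800 nM

The three compounds share one core and differ only in the length of the saturated chain on the amide. On the numbers shown, compound 3 stands lowest of the three in this assay, but both steps to it are small: a 1.5-fold lower number from compound 1 to compound 3 (0.19 log units; within the scatter) and a 1.4-fold lower number from compound 2 to compound 3 (0.14 log units; within the scatter), with a 1.1-fold lower number from compound 1 to compound 2 (0.05 log units; within the scatter) between the other two. None of these steps is beyond the scatter, so no real ranking can be claimed among compound 1, compound 2 and compound 3.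

Compound 4, `CCCCCCCCCCCCCC(=O)NCC(C)(C)CC1=C(O)C(=O)c2ccccc2C1=O`, has not yet been measured. Compared with compound 3 the change is ethyl in place of hydrogen on a saturated chain carbon, ten or more bonds along the chain from a carbonyl carbon, that is, the chain is extended once more. The three measured steps all bear on it, since each also lengthens this chain, and each stayed within the scatter. The same is therefore expected here: little or no change in this assay, perhaps a slightly lower number. Compound 4 is expected at 10000 nM, between 5000 nM and 25000 nM. That estimate corresponds to an expected step of a 1.3-fold lower number from compound 3 to compound 4 (0.11 log units; within the scatter).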

Compound 4, half-maximal inhibitory concentration: 25100 nM
The estimate for compound 4 lay 2.5-fold (0.40 log units) below the measured number; measured number above the stated range.
By their numbers in this assay, from the lowest: compounds 3, 2, 1 and 4 (each within the scatter of the next).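

In this assay, within the data shown here, the ethyl added at this place gives the largest step seen so far (a 2.0-fold higher number from compound 3 to compound 4 (0.29 log units; within the scatter)), and it is the first step printed toward a higher number from the compound before it, yet it too stays within the scatter. The wider comparisons with the shorter chains are smaller (a 1.4-fold higher number from compound 2 to compound 4 (0.15 log units; within the scatter); a 1.3-fold higher number from compound 1 to compound 4 (0.11 log units; within the scatter)), so no trend with chain length can be claimed across these four compounds, and a propyl change read on two chains also shows no real difference: the same change on two cores in this assay, a 1.5-fold lower number (0.19 log units; within the scatter) from compound 1 to compound 3 and a 1.4-fold higher number (0.15 log units; within the scatter) from compound 2 to compound 4, 2.2-fold (0.34 log units) apart, within the scatter of two such steps. The ethyl change read on two chains shows the same, so its apparent reversal cannot be taken as real: the same change on two cores in this assay, a 1.1-fold lower number (0.05 log units; within the scatter) from compound 1 to compound 2 and a 2.0-fold higher number (0.29 log units; within the scatter) from compound 3 to compound 4, 2.2-fold (0.34 log units) apart, within the scatter of two such steps.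

On these data alone, whether a still longer chain, or a chain ending in an amine or a carboxylic acid, would move the number beyond the scatter stays open. The shared core is the same in all four compounds, so what a change to it would do cannot be read from them.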